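Compound 3: trichloromethyl on the chain carbon

This account rests on a few compounds, and the source may have more. Where it says the series, first, only, none or still open, it means among the compounds named here.

Measured so far:
- compound 1 `CC(C)COC(=O)N1CCN(C(=O)c2nc(Nc3cc(C4CC4)[nH]n3)c3cc(Cl)ccc3n2)C[C@H]1C` gives 73.7%
- compound 2 `COC(=O)N1CCN(C(=O)c2nc(Nc3cc(C4CC4)[nH]n3)c3cc(Cl)ccc3n2)C[C@H]1C` gives 84.6%

In an ADME assay on a cell-free system (plasma, Homo sapiens), read by HPLC, with a stated time of 120 min, at 37 degrees C (a lower number here means that less of the compound is left, a higher number that more of the compound is left), compound 2 stands highest of the two at 84.6% and compound 1 lies beyond the scatter under it. Still unmeasured is compound 3 `C[C@@H]1CN(C(=O)c2nc(Nc3cc(C4CC4)[nH]n3)c3cc(Cl)ccc3n2)CCN1C(=O)OCC(Cl)(Cl)Cl`, which differs from compound 2 by trichloromethyl in place of hydrogen on a saturated chain carbon bound to an oxygen next to a carbonyl group and so has trichloromethyl in place of hydrogen on a saturated chain carbon bound to an oxygen next to a carbonyl group.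

Within the data shown here, only one measured step bears on this place. It is a number 10.9 percentage points higher from compound 1 to compound 2 (beyond the scatter) with hydrogen in place of isopropyl. Read backwards, it shows a substituent on this carbon going with a lower number, as compound 1 with isopropyl reads 73.7% here. Among the measured compounds shown here, no measured compound carries chlorine on this chain, so a single step is thin support. A modest fall is therefore expected, though with wide uncertainty. The estimated step is a number 13.6 percentage points lower from compound 2 to compound 3 (beyond the scatter) in this assay on this reading. For compound 3 the expected value is 71% with an estimated range from 50% to 86% as the likely span.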

Compound 3, percent of the compound remaining: 79%
Estimate against measurement, compound 3: 8 percentage points below; the measured number falls inside the stated range.
By their numbers in this assay, from the lowest: compounds 1, 3 and 2 (each within the scatter of the next, the first and the last beyond it).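

In this assay, trichloromethyl on the saturated chain carbon bound to an oxygen next to a carbonyl group gives a number 5.6 percentage points lower from compound 2 to compound 3 (within the scatter), and exchanging isopropyl for trichloromethyl at the same carbon gives a number 5.3 percentage points higher from compound 1 to compound 3 (within the scatter). Compound 3 therefore cannot be separated from either neighbour, although compound 1 and compound 2 lie beyond the scatter of each other, so the earlier pair does not establish a general rule that any group on this carbon lowers the amount of compound left: isopropyl is separated from hydrogen here, while trichloromethyl is not. Nothing shown gives a reason for this difference between the two groups, and with three compounds it remains a description of this series only.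

Still open, from the compounds shown here alone, is whether trifluoromethyl, a longer chain, an amine or a carboxylic acid on this carbon would stay within the scatter of hydrogen or fall beyond it. Also open, going by these compounds, is whether the same readings would hold if the oxygen and carbonyl linking this chain to the shared core were replaced by a plain amide.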